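A few compounds are considered here, and "the series" means these few. Any claim that something is new, unique, unknown or untested is made for them only; others in the source may bear on it.

Compound 3, `C[C@H](c1cccc(Cl)c1)N(Cc1cccc(C(=O)O)c1)C(=O)c1cnc2ccccc2c1`, gives the lowest of the two numbers obtained so far: in an assay on CHO T-rex cells for antagonist activity at transient receptor potential cation channel subfamily M member 8 (Homo sapiens), read by calcium flux, with a stated time of 20 min (on this read-out higher numbers stand for weaker inhibition and lower numbers for stronger inhibition), compound 3 gives 62 nM. Its nearest neighbour is compound 2, `COc1ccc(C(C)N(Cc2cccc(C(=O)O)c2)C(=O)c2cnc3ccccc3c2)cc1`, which in this assay gives 6100 nM, so there is a 98-fold lower number from compound 2 to compound 3 (1.99 log units; beyond the scatter). Compound 1, `O=C(O)c1cccc(CN(Cc2ccc(F)cc2)C(=O)c2cnc3ccccc3c2)c1`, yields only a limit in this assay, namely > 9350 nM, a value at which one of the three results sits (the limit of > 9350 nM in this assay, at which 1 of the 3 values shown sits). From that limit to compound 3 there is an at least 150-fold lower number from compound 1 to compound 3 (2.17 log units; beyond the scatter).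

Compound 4, `CC[C@H](c1ccc(C)o1)N(Cc1cccc(C(=O)O)c1)C(=O)c1cnc2ccccc2c1`, differs from compound 3 by 1-(5-methylfuran-2-yl)propyl in place of 1-(3-chlorophenyl)ethyl on an amide-type nitrogen. The two measured steps that bear on this position, from compound 1 to compound 3 and from compound 2 to compound 3, both changed the group on this same nitrogen and were both large, which shows that this position moves the number strongly. None of them, however, tested a five-membered ring in place of the six-membered one, so the direction of this new step is uncertain; a weakening seems more likely than a further gain. Compound 4 is therefore expected to give 600 nM, within a range from 120 nM to 3000 nM, which would mean a 9.7-fold higher number from compound 3 to compound 4 (0.99 log units; beyond the scatter).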

Compound 4, half-maximal inhibitory concentration: 328 nM
Estimate against measurement, compound 4: 1.8-fold (0.26 log units) above; measured number inside the range.
By their numbers in this assay, from the lowest: compound 3; then compound 4; then compound 2. At a limit, above all of these: compound 1.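

The earlier steps shown here changed only the substituents on a six-membered ring, and this result shows that the amide-type nitrogen also tolerates a five-membered aromatic ring with a hetero atom: in this assay there is a 5.3-fold higher number from compound 3 to compound 4 (0.72 log units; beyond the scatter), a modest loss, while there is also a 19-fold lower number from compound 2 to compound 4 (1.27 log units; beyond the scatter). Ring size alone therefore does not set the order, since the six-membered 1-(3-chlorophenyl)ethyl group lies on one side of the furan group and the six-membered 1-(4-methoxyphenyl)ethyl group on the other. The step from the 4-fluorobenzyl group starts from a limit of the assay and so gives only a floor, an at least 28-fold lower number from compound 1 to compound 4 (1.45 log units; beyond the scatter), and nothing shown explains why any of these groups ranks where it does.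

The new group differs from 1-(3-chlorophenyl)ethyl in both its ring and its chain, so the shares of the furan ring and of the propyl chain cannot be told apart; 1-(5-methylfuran-2-yl)ethyl or 1-(3-chlorophenyl)propyl would separate them. Also open, as far as these compounds go, is how a thiophene ring, or a furan ring bearing chlorine in place of methyl, would behave on this nitrogen.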